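Dropping the Methoxy Group: From Compound 2 to Compound 4

A few compounds are considered here, and "the series" means these few. Any claim that something is new, unique, unknown or untested is made for them only; others in the source may bear on it.

Of the compounds shown here, three have been tested in a functional assay on MCF7 cells (Homo sapiens) for antiproliferative activity, read by sulforhodamine B assay, with a stated time of 72 h, tested at 10 uM; on this read-out higher numbers stand for a weaker effect at the one concentration tested and lower numbers for a stronger effect. Compound 1 `COC(=O)C1=C(N)Oc2ccc(Br)cc2C1CC(=O)c1ccc(Br)cc1` gives 72.5%, compound 2 `COc1cc(Br)cc2c1OC(N)=C(C#N)C2CC(=O)c1ccc(Br)cc1` gives 39.7%, and compound 3 `COc1cc(Br)cc2c1OC(N)=C(C#N)C2CC(=O)c1ccc(C)cc1` gives 116%. Among these numbers compound 2 stands lowest, that is, it shows the strongest effect of the three in this assay.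

Compound 4 `N#CC1=C(N)Oc2ccc(Br)cc2C1CC(=O)c1ccc(Br)cc1` is compound 2 with one change: hydrogen in place of methoxy on an aromatic carbon. Within the data shown here, no measured step concerns this kind of change. Among the measured compounds shown here, the only measured step, a number 76.3 percentage points higher from compound 2 to compound 3 (beyond the scatter), concerns a different group on a different ring and so does not bear on it. Compound 1, which also lacks a methoxy group but carries a methyl ester where compound 4 carries a nitrile, gives a number well above that of compound 2, but the two differences between them cannot be separated.

For the measured compounds named here, with no step to lean on, the expectation for compound 4 in this assay is a number somewhat above compound 2, about 55%, within 30% to 85%, an expected step of a number 15.3 percentage points higher from compound 2 to compound 4 (beyond the scatter), wide and uncertain.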

Compound 4, a percentage reported as activity, at one concentration (the size of the read-out at that concentration, not a potency): 47.2%
The estimate for compound 4 lay 7.8 percentage points above the measured number; low and high end bracket the measured number.
By their numbers in this assay, from the lowest: compounds 2 and 4 (each within the scatter of the next); then compound 1; then compound 3.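

In this assay, the methoxy group can be replaced by hydrogen with no change beyond the usual scatter, as shown by a number 7.5 percentage points higher from compound 2 to compound 4 (within the scatter), so at this position, ortho to a fused ring, the effect at this one concentration does not depend on the methoxy group. Compound 4 also allows a comparison that differs in one place only, and it shows a number 25.3 percentage points lower from compound 1 to compound 4 (beyond the scatter), so on this double-bonded ring carbon, cyano goes with a stronger effect than methoxycarbonyl in this pair. No measurement available here explains either step.

Going by these compounds, it remains open whether other groups at the methoxy position, such as an amine or a longer ether chain, would also leave the read-out unchanged. On these data alone, it also remains open whether methyl in place of bromo on the other aromatic ring would have as large an effect in a compound without the methoxy group.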